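Swapping phenyl for cyclopropyl on the amine of compound 1

The compounds below may be only part of what the source reports. "The series", "measured", "known", "first", "only" and "open" are said of these compounds alone.

Compound 1 `CC(=O)NC[C@H]1CN(c2ccc(OC[C@H](O)CNc3ccccc3)c(F)c2)C(=O)O1` gives 0.59 in a physicochemical assay for lipophilicity, read by HPLC; on this read-out higher numbers stand for higher lipophilicity and lower numbers for lower lipophilicity.
Compound 2 `CC(=O)NC[C@H]1CN(c2ccc(OC[C@@H](O)CNc3cc(C(F)(F)F)cc(C(F)(F)F)c3)c(F)c2)C(=O)O1` gives 3.1 in this assay.
Compound 3 `CC(=O)NC[C@H]1CN(c2ccc(OC[C@H](O)CNc3cc(C(F)(F)F)cc(C(F)(F)F)c3)c(F)c2)C(=O)O1` gives 3.01 in this assay.

Among these three, compound 1 stands lowest in this assay; compound 3 sits higher by a margin beyond the scatter, and compound 2 higher still. Compounds 2 and 3 show a number 0.09 log units lower from compound 2 to compound 3 (within the scatter), a step within the scatter, which fits (the fact that compounds 2 and 3 differ only in the configuration as drawn).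

The compound not yet measured, compound 4 `CC(=O)NC[C@H]1CN(c2ccc(OC[C@H](O)CNC3CC3)c(F)c2)C(=O)O1`, differs from compound 1 in one place: cyclopropyl in place of phenyl on an amine nitrogen. Going by the values given here, none of the measured steps bears on this change, since the only measured step concerns configuration alone, and compounds 2 and 3 carry the same anilino group as compound 1 with two trifluoromethyl groups added rather than replaced. Among the compounds with values here, no measured pair therefore sets the size or direction of the step to compound 4; the estimate rests on compound 1 alone as its nearest neighbour. The expected step is a number 0.89 log units lower from compound 1 to compound 4 (beyond the scatter), and compound 4 is estimated at -0.3, in a range from -1.2 to 0.5.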

Compound 4, partition coefficient: -0.1
Beside the measured number, compound 4's estimate is 0.20 log units below it; measured number inside the range.
By their numbers in this assay, from the lowest: compound 4; then compound 1; then compounds 3 and 2 (each within the scatter of the next).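

Going by these compounds alone, compound 4 gives the first measured reading of what replacing the group on this amine nitrogen does in this assay, where the earlier compounds had offered a step in configuration alone. Putting one three-membered non-aromatic ring in place of one six-membered aromatic ring gives a number 0.69 log units lower from compound 1 to compound 4 (beyond the scatter), so the aromatic ring can be replaced here with a modest step down, beyond the scatter. The evidence at hand concerns only configuration and does not bear on this change.

On these data alone, how a cyclobutyl, a benzyl or an isopropyl group on the same amine nitrogen would stand in this assay stays open. So does whether cyclopropyl in place of the substituted anilino ring of compound 3 would give a step of similar size.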